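Amide nitrogen substituent and Bcl-2 binding in the series

The source may report more compounds than this note shows. Statements on the series, on what has been measured and on what is new or still open speak of the compounds shown alone.

Compound 1 `CC(C)=CCCC1=CC[C@@H](C(=O)NO)[C@H](c2ccccc2)C1` in an assay on isolated protein for inhibition of Apoptosis regulator Bcl-2 (Homo sapiens), read by fluorescence polarization, with stated times of 5 min and 10 min (on this read-out lower numbers stand for stronger inhibition and higher numbers for weaker inhibition), gives 700 nM. Compound 2 `CC(C)=CCCC1=CC[C@@H](C(=O)NCCC(=O)O)[C@H](c2ccccc2)C1` reaches only a limit in this assay, > 23000 nM. Among the measured compounds shown here, the single measured step, an at least 32-fold higher number from compound 1 to compound 2 (1.51 log units; beyond the scatter), rests on (the limit of > 23000 nM in this assay, at which 1 of the 2 values shown sits), so its true size is not fixed. Compound 3 `COC(=O)c1ccc(NC(=O)[C@@H]2CC=C(CCC=C(C)C)C[C@H]2c2ccccc2)cc1` carries 4-(methoxycarbonyl)phenyl in place of 2-carboxyethyl on an amide-type nitrogen. For the measured compounds named here, no measured step covers an aryl group on this nitrogen; compound 2 sits at a limit and the direction of any step from it is open. Compound 3 is expected at 10000 nM, within 2000 nM to 50000 nM. The estimated step of an at least 2.3-fold lower number from compound 2 to compound 3 (0.36 log units; beyond the scatter) comes with a fair chance that only a limit is reported again.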

Compound 3, inhibition constant: > 23000 nM
Compound 3 ended at the assay's limit; the forecaster's own chance of this, stated with the estimate: 50%; at least 2.3-fold (0.36 log units) between middle value and limit.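

Hydroxy is not replaced successfully by an aryl group either: 4-(methoxycarbonyl)phenyl in place of hydroxy on an amide-type nitrogen gives an at least 32-fold higher number from compound 1 to compound 3 (1.51 log units; beyond the scatter) in this assay, matching the loss seen with 2-carboxyethyl. The step between compound 2 and compound 3 cannot be read. Among the compounds shown, only compound 1 gives a number rather than a limit: the limit of > 23000 nM in this assay, at which 2 of the 3 values shown sit.

On these data alone, how far compound 2 and compound 3 lie beyond the limit remains open. Also open, as far as these compounds go, is whether methoxy or 4-carboxyphenyl on this nitrogen would keep measurable binding.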